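Notes on the step from compound 2 to compound 4

The source may hold more compounds than are shown below. What is called first, only, known or untested is meant among the compounds shown, and "the series" means these compounds.

In a physicochemical assay for lipophilicity, at pH 7.4 (a higher number here means a more lipophilic compound, a lower number a more polar compound), compound 1 (`Cc1cc(C(=O)O)nn1C(C)c1cc(Cl)ccc1OCc1ccccc1`) gives 1 and compound 3 (`Cc1cc(C(=O)NN2CCOCC2)nn1Cc1cc(Cl)ccc1OCC(C)C`) gives 3.1. Compound 2 (`Cc1cc(C(=O)Nc2ccccn2)nn1Cc1cc(Cl)ccc1OCc1ccccc1`) reads > 3.7, which is a limit of the assay and not a number.

Compound 4 (`Cc1cc(NC(=O)CC(C)(C)C)nn1Cc1cc(Cl)ccc1OCc1ccccc1`) has not yet been measured. It differs from compound 2 on an aromatic carbon of the shared core, where (neopentylcarbonyl)amino stands in place of (pyridin-2-yl)carbamoyl: (neopentylcarbonyl)amino in place of (pyridin-2-yl)carbamoyl on an aromatic carbon.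

Going by the values given here, no two measured compounds differ in one place only, so no measured step gives a guide to the size of this change. The expectation rests on compound 2 at > 3.7, again a limit and not a number. The expected step that the limit leaves unreadable from compound 2 to compound 4 is small, within the scatter, with no firm direction. A report of compound 4 as a limit alone is also expected to be more likely than not. For compound 4 the estimate in this assay is 3.9, with an expected range of 3.4 to 4.5.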

Compound 4, distribution coefficient: > 3.7
Compound 4 gave a limit, no number; the forecaster's own chance of this, stated with the estimate: 60%; the middle value does not contradict the limit.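

In this assay compound 4 reads > 3.7 as a limit and not a number; compound 2 also reads as a limit, so no step between compound 2 and compound 4 can be read: the limit of > 3.7 in this assay, at which 2 of the 4 values shown sit.

From the compounds shown here alone, whether (neopentylcarbonyl)amino in place of (pyridin-2-yl)carbamoyl shifts this assay at all, and in which direction, stays open.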